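Furan for thiophene on a nucleoside series with no measured activity

The compounds below may be only part of what the source reports. "The series", "measured", "known", "first", "only" and "open" are said of these compounds alone.

Working notes on three measured nucleoside analogues and one untested congener, all read in a functional assay on HepG2 cells (Homo sapiens) for antiproliferative activity, read by XTT assay, with a stated time of 72 h; on this read-out lower numbers stand for stronger inhibition and higher numbers for weaker inhibition. Compound 1 `Nc1nc(N)c2c(-c3ccoc3)cn([C@@H]3O[C@H](CO)[C@@H](O)[C@H]3O)c2n1` reaches only a limit of the assay, giving > 20000 nM. Compound 2 `COc1nc(N)nc2c1c(-c1ccccc1)cn2[C@@H]1O[C@H](CO)[C@@H](O)[C@H]1O` likewise stops at a limit, with > 20000 nM. Compound 3 `O=c1[nH]cnc2c1c(-c1ccsc1)cn2[C@@H]1O[C@H](CO)[C@@H](O)[C@H]1O` also returns a limit rather than a number, at > 15000 nM. So compound 3 stands among values that are all limits: one sits at the limit of > 15000 nM in this assay, at which 1 of the 3 values shown sits, and two more at the limit of > 20000 nM in this assay, at which 2 of the 3 values shown sit, and no step between measured compounds can be drawn from them.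

The untested compound 4 `O=c1[nH]cnc2c1c(-c1ccco1)cn2[C@@H]1O[C@H](CO)[C@@H](O)[C@H]1O` differs from compound 3 in one place: furan-2-yl in place of thiophen-3-yl on an aromatic carbon. Going by the values given here, no measured step exists to calibrate this change, and the three limits give no direction. The step from compound 3 to compound 4 is therefore expected to be none beyond the usual scatter, with a step that the limit leaves unreadable from compound 3 to compound 4 as the estimate. Compound 4 is expected in this assay at 20000 nM, within a range from 6000 nM to 80000 nM, and most likely the assay will again report only a limit rather than a number.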

Compound 4, half-maximal inhibitory concentration: > 15000 nM
Compound 4: a limit, no number; the forecaster's own chance of this, stated with the estimate: 80%; the middle value is on the limit's open side.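

Compound 3 and compound 4 both return only limits of the assay in this assay, so no step can be read for furan-2-yl in place of thiophen-3-yl. The compounds shown leave open whether any member of this series gives a measurable inhibition in this read-out, and whether that exchange would then shift it in either direction.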